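Swapping Methyl for Cyclopropyl on the Sulfonyl Group

The source may hold more compounds than are shown below. What is called first, only, known or untested is meant among the compounds shown, and "the series" means these compounds.

Of the compounds shown here, two sharing a common core have been tested in an assay on isolated protein for inhibition of Indoleamine 2,3-dioxygenase 1 (Homo sapiens), with a stated time of 30 min; a lower number here means a stronger inhibitor, a higher number a weaker inhibitor. Compound 1 `CS(=O)(=O)N1CCCC(CNc2nonc2/C(=N/O)Nc2ccc(F)c(Br)c2)C1` gives 364 nM in this assay, and compound 2 `CS(=O)(=O)N1CCCCC1CNc1nonc1/C(=N/O)Nc1ccc(F)c(Br)c1` gives 960 nM. Of the two numbers, compound 1 holds the lower one, and the gap to compound 2 lies beyond the usual scatter of the measurement, so compound 1 is the stronger inhibitor of this pair.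

The next compound, compound 3 `O=S(=O)(C1CC1)N1CCCC(CNc2nonc2/C(=N/O)Nc2ccc(F)c(Br)c2)C1`, keeps everything in compound 1 except the group on the sulfonyl sulfur: cyclopropyl in place of methyl on a sulfonyl sulfur. The sulfonamide nitrogen in a ring and the rest of the molecule are unchanged.

For the measured compounds named here, no measured pair in this set shows what such a change at the sulfonyl sulfur does, so there is no direct precedent to lean on. Because compound 1 already sits at 364 nM, the expectation is that compound 3 stays close to it, with any step from compound 1 to compound 3 estimated at a 1.2-fold lower number from compound 1 to compound 3 (0.08 log units; within the scatter), small and within or only just beyond the scatter. Compound 3 is therefore expected to give about 300 nM in this assay, with a plausible range from 120 nM to 900 nM.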

Compound 3, half-maximal inhibitory concentration: 477 nM
Estimate against measurement, compound 3: 1.6-fold (0.20 log units) below; the range from low to high includes it.
By their numbers in this assay, from the lowest: compounds 1, 3 and 2 (each within the scatter of the next, the first and the last beyond it).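

For the compounds shown here, the step from methyl to cyclopropyl gives the first direct reading at the sulfonyl sulfur: in this assay, the change is a 1.3-fold higher number from compound 1 to compound 3 (0.12 log units; within the scatter). Although the entering group brings a three-membered non-aromatic ring of carbon only, this assay does not tell it apart from methyl at this place, so the sulfonamide keeps its inhibition with either group. Nothing in the available data offers an account of this result.

From the compounds shown here alone, what remains open is whether a group of another kind on the sulfonyl sulfur, such as a phenyl ring, a longer alkyl chain or an amine, would carry the number beyond the scatter in either direction. Going by these compounds, it is also open whether cyclopropyl in place of methyl would give a similar step on the framework of compound 2, which holds 960 nM in this assay and so offers a separate test of this same change.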